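Extending the chain on a shared core: from compound 2 to compound 3

A few compounds are considered here, and "the series" means these few. Any claim that something is new, unique, unknown or untested is made for them only; others in the source may bear on it.

Measured so far:
compound 1, `CCc1nnc2sc(-c3cccc(F)c3)nn12`: 13%
compound 2, `CCCc1nnc2sc(-c3cccc(F)c3)nn12`: 35%

Both compounds were tested in an assay for inhibition of histone-lysine N-methyltransferase, H3 lysine-79 specific (Homo sapiens), with stated times of 15 min and 120 min, tested at 50 uM; a lower number here means less inhibition, a higher number more inhibition at the concentration tested (going by the name of the read-out). Compound 2 stands highest of the two numbers; its nearest neighbour is compound 1, and the step of a number 22 percentage points higher from compound 1 to compound 2 (beyond the scatter) lies beyond the scatter. That single step is the only one that bears on the move to compound 3, `Cc1ccccc1Cc1nnc2sc(-c3cccc(F)c3)nn12`, which differs from compound 2 by 2-methylphenyl in place of ethyl on a saturated chain carbon bound to an aromatic carbon. The one step shown, methyl in place of hydrogen on a saturated chain carbon, two bonds along the chain from an aromatic carbon, gave a modest rise; a larger group entering at the same place is therefore expected to keep the number at least where compound 2 stands, more likely somewhat higher, though no measured step covers a group of this size. Compound 3 is expected to give 45%, between 15% and 75%, a step of a number 10 percentage points higher from compound 2 to compound 3 (within the scatter).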

Compound 3, a percentage reported as inhibition, at one concentration (the size of the read-out at that concentration, not a potency): 27%
Compound 3: the middle estimate sits 18 percentage points above what was measured; the range from low to high includes it.
By their numbers in this assay, from the lowest: compound 1; then compounds 3 and 2 (each within the scatter of the next).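

In this assay, replacing ethyl with 2-methylphenyl on the saturated chain carbon bound to an aromatic carbon gives a number 8 percentage points lower from compound 2 to compound 3 (within the scatter), so this position accepts a group with a six-membered aromatic ring and seven heavy atoms without a change that can be told from the scatter. Set against the shorter chain, the same group gives a number 14 percentage points higher from compound 1 to compound 3 (beyond the scatter), which shows that the step up from compound 1 is not confined to the saturated chain of compound 2. Nothing available accounts for either step.

As far as these compounds go, what an unsubstituted phenyl, a butyl chain or an amine would give at this place remains open, as does what the methyl on the ring contributes. Each number is a single reading at one concentration, so the potency of these compounds also remains open.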